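Methoxy in place of fluoro on the anilino ring

This account rests on a few compounds, and the source may have more. Where it says the series, first, only, none or still open, it means among the compounds named here.

Measured so far:
compound 1, `COc1ccc(S(C)(=O)=O)c(NCC2=NCCN2)c1`, < 6310 nM (a limit)
compound 2, `CSc1ccc(C)cc1NCC1=NCCN1`, 977 nM
compound 3, `CSc1ccc(F)cc1NCC1=NCCN1`, 331 nM

In an assay on CHO cells for binding affinity to Alpha-2B adrenergic receptor (Homo sapiens), read by radioligand binding (a lower number here means a stronger inhibitor, a higher number a weaker inhibitor), compound 3 gives 331 nM, the lowest of the two numbers at hand. Compound 2 gives 977 nM in this assay. For the measured compounds named here, the only one-place step among the measured compounds is a 3.0-fold lower number from compound 2 to compound 3 (0.47 log units; beyond the scatter). Going by the values given here, for compound 1 this assay reports only a limit, < 6310 nM; this is the limit of < 6310 nM in this assay, at which 1 of the 3 values shown sits, and no step to it can be sized.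

Compound 4, `COc1ccc(SC)c(NCC2=NCCN2)c1`, has not yet been measured. It differs from compound 3 in one place: methoxy in place of fluoro on an aromatic carbon. Among the compounds with values here, no measured step exchanges fluoro for methoxy, so the step of a 3.0-fold lower number from compound 2 to compound 3 (0.47 log units; beyond the scatter) is the only guide: another group on that aromatic carbon gave a modestly higher number than fluoro did. Compound 4 is therefore expected to sit somewhat higher than compound 3, by an estimated step of a 2.4-fold higher number from compound 3 to compound 4 (0.38 log units; beyond the scatter), though the change could also fall within the scatter. For compound 4 the estimate in this assay is 800 nM, in the range 250 nM to 2500 nM.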

Compound 4, inhibition constant: < 6310 nM
Compound 4: no number, only a limit (the forecaster's own chance of this, stated with the estimate: 5%); the middle value does not contradict the limit.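

In this assay, for the compounds shown here, compound 4 gives < 6310 nM, which is a limit and not a number: the limit of < 6310 nM in this assay, at which 2 of the 4 values shown sit. No step from compound 1, compound 2 or compound 3 to compound 4 can be read. The compounds shown leave open how methoxy in place of fluoro on that aromatic carbon changes the number.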